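The compounds below may be only part of what the source reports. "The series", "measured", "known", "first", "only" and "open" are said of these compounds alone.

Measured so far:
compound 1, `Fc1cc(Cl)ccc1-c1ccc(Cn2nnc3ccccc32)cn1`: 0.8 mL/min/g
compound 2, `Fc1cc(Cl)ccc1-c1ccc(Cn2nnc3c(C(F)(F)F)cccc32)cn1`: 0.2 mL/min/g
compound 3, `Brc1cccc2c1nnn2CC1CC1`: 0.6 mL/min/g

In an ADME assay on microsomes from liver (Rattus norvegicus, strain Wistar) for metabolic stability, tested at 2.5 uM (on this read-out higher numbers stand for fast clearance and lower numbers for slow clearance), compound 1 gives 0.8 mL/min/g and compound 2 gives 0.2 mL/min/g. The two differ by trifluoromethyl in place of hydrogen on an aromatic carbon, and that change made a step of a 4.0-fold lower number from compound 1 to compound 2 (0.60 log units; beyond the scatter). Compound 3 gives 0.6 mL/min/g in this assay; the difference between its core and the core of compound 1 is not broken down here. Compound 4, `FC(F)(F)c1cc(Br)c2nnn(CC3CC3)c2c1`, has not yet been measured in this assay. It differs from compound 3 by trifluoromethyl in place of hydrogen on an aromatic carbon. Among the compounds with values here, this is the same kind of change as the one between compound 1 and compound 2, but the surroundings differ: in compound 4 the trifluoromethyl sits meta to a bromo group, meta to a fused ring and para to a fused ring, whereas in compound 2 it sits ortho to a fused ring and meta to a fused ring. The expectation rests on the step of a 4.0-fold lower number from compound 1 to compound 2 (0.60 log units; beyond the scatter) and on the value of compound 3, 0.6 mL/min/g. Compound 4 is expected to move by a 2.4-fold lower number from compound 3 to compound 4 (0.38 log units; beyond the scatter). The estimate for compound 4 is 0.25 mL/min/g, most likely between 0.1 mL/min/g and 0.6 mL/min/g.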

Compound 4, intrinsic clearance in a liver preparation (reported as CLH), per the amount of preparation that the assay uses: 0.2 mL/min/g
Compound 4: middle estimate off by 1.3-fold (0.10 log units), on the high side; low and high end bracket the measured number.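

In this assay, trifluoromethyl in place of hydrogen on an aromatic carbon made a step of a 3.0-fold lower number from compound 3 to compound 4 (0.48 log units; beyond the scatter), so the number fell on this second core as well. Set beside the earlier step, the change carried from one core to the other in direction and, within the scatter, in size: the same change on two cores in this assay, a 4.0-fold lower number (0.60 log units; beyond the scatter) from compound 1 to compound 2 and a 3.0-fold lower number (0.48 log units; beyond the scatter) from compound 3 to compound 4, 1.3-fold (0.12 log units) apart, within the scatter of two such steps This agreement rests on two pairs only, with the trifluoromethyl in different surroundings on each core, so it neither separates the effect of its place from that of the core nor shows that the step would hold on any further core, and it gives no reason why the number falls.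

The compounds shown leave open whether a different group on the same aromatic carbon, such as a nitrile or a methyl, would lower the number as well. They also leave open how the number would respond if an amine replaced the bromo group of compound 4.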